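The source may hold more compounds than are shown below. What is called first, only, known or untested is meant among the compounds shown, and "the series" means these compounds.

Compound 1, `Cc1ccc(Cn2cc(C(=N)S)c3c(N)ncnc32)cc1`, gives 65000 nM in a functional assay on KB cells (Homo sapiens) for cytotoxicity; a higher number here means a weaker inhibitor, a lower number a stronger inhibitor.
Compound 2, `C=CCn1cc(C(N)=S)c2c(N)ncnc21`, gives 19000 nM in this assay.
Compound 3, `COc1ccc(Cn2cc(C(N)=O)c3c(N)ncnc32)cc1`, gives 47000 nM in this assay.

Among these three, compound 2 has the lowest number, so it is the strongest inhibitor of the set; its nearest neighbour is compound 3, and compound 1 lies furthest from it, both differences being beyond the scatter of repeated measurements. All three numbers are high, so none of these compounds is a potent cytotoxic agent in this assay.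

Compound 4, `NC(=S)c1c[nH]c2ncnc(N)c12`, has not yet been measured. It differs from compound 2 in one place: hydrogen in place of allyl on an aromatic nitrogen. Going by the values given here, no pair of measured compounds shows what such a change does, so the size of the step has to be guessed. The three measured compounds all carry a group on that aromatic nitrogen, and removing it leaves the shared core bare. The expectation is a modest move toward a weaker inhibitor, with the step from compound 2 to compound 4 estimated at a 2.1-fold higher number from compound 2 to compound 4 (0.32 log units; beyond the scatter) in this assay. Compound 4 is therefore expected to give about 40000 nM, within a range of 12000 nM to 130000 nM.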

Compound 4, half-maximal inhibitory concentration: 25000 nM
Compound 4: the middle estimate sits 1.6-fold (0.20 log units) above what was measured, within the range that was stated.
By their numbers in this assay, from the lowest: compounds 2, 4, 3 and 1 (each within the scatter of the next, the first and the last beyond it).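

Until now, every measured compound carried a group on the aromatic nitrogen, so nothing showed whether the shared core could do without one. Putting hydrogen in place of allyl there gives a 1.3-fold higher number from compound 2 to compound 4 (0.12 log units; within the scatter) in this assay, so in this pair the allyl group is not needed for the weak cytotoxicity seen. Nothing available explains this result.

Compounds 1 and 3 carry larger groups on that nitrogen, but they also differ from the others in a second place, so their numbers cannot be read as steps at this position. Still open, as far as these compounds go, is whether a longer chain, a chain ending in an amine or a carboxylic acid on that nitrogen would stay in this same weak range or move clearly away from it.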